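Clearance notes on the aryl exchange toward compound 4

The source may report more compounds than this note shows. Statements on the series, on what has been measured and on what is new or still open speak of the compounds shown alone.

Within the data shown here, compound 2 `CNc1nc(NCCCN(C)C)c2sc(-c3ccc(C(F)(F)F)cc3)cc2n1` gives 14 uL/min in an ADME assay (liver) for metabolic stability, with Liver microsome (Homo sapiens) as the target, read by LC-MS, using microsomes, tested at 1 uM (a lower number here means slower removal, a higher number faster removal of the compound), and holds the lowest of the three numbers so far, with compound 1 `CNc1nc(NCCCN(C)C)c2sc(-c3ccc(S(C)(=O)=O)cc3)cc2n1` at 15 uL/min within the scatter of it and compound 3 `CNc1nc(NCCCN(C)C)c2sc(-c3cccc4cnccc34)cc2n1` at 68.7 uL/min the furthest away, beyond the scatter. Compound 4 `CNc1nc(NCCCN(C)C)c2sc(-c3ccc(N4CCNCC4)cc3)cc2n1` differs from compound 2 by piperazin-1-yl in place of trifluoromethyl on an aromatic carbon. Among the measured compounds shown here, the one measured step at the same aromatic carbon, a 1.1-fold lower number from compound 1 to compound 2 (0.03 log units; within the scatter), shows no shift beyond the scatter; compound 3 carries a different ring system and does not bear on this exchange. For the measured compounds named here, no measured step sets piperazin-1-yl against trifluoromethyl, so the direction stays open. For compound 4 a number close to the starting point is expected, a 1.4-fold higher number from compound 2 to compound 4 (0.15 log units; within the scatter). The estimate for compound 4 is 20 uL/min, with a range from 8 uL/min to 45 uL/min.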

Compound 4, intrinsic clearance in a liver preparation (reported as CLH), per the amount of preparation that the assay uses: 36 uL/min
Beside the measured number, compound 4's estimate is 1.8-fold (0.26 log units) below it; measured number inside the range.
By their numbers in this assay, from the lowest: compounds 2 and 1 (each within the scatter of the next); then compounds 4 and 3 (each within the scatter of the next).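

In this assay the steps of a 2.6-fold higher number from compound 2 to compound 4 (0.41 log units; beyond the scatter) and a 2.4-fold higher number from compound 1 to compound 4 (0.38 log units; beyond the scatter) are both modest, yet they give this aromatic carbon its first change beyond the scatter. Trifluoromethyl and methylsulfonyl had stayed within the scatter of each other, while piperazin-1-yl gives the higher number against both, so the position does respond to the group placed on it. Nothing measured here accounts for the shift. Still open, as far as these compounds go, is whether morpholine, or a piperazine with a methyl on its second nitrogen, stays near compound 4 or returns toward compound 2.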